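A methyl for isopropyl at the assay limit

The source may hold more compounds than are shown below. What is called first, only, known or untested is meant among the compounds shown, and "the series" means these compounds.

Compound 1 `CC(C)[C@H](NC(=O)c1cc(Cl)ccc1OCCN)C(=O)Nc1ccc([N+](=O)[O-])cc1Cl` gives > 10000 nM in a functional assay on MCF7 cells (Homo sapiens) for inhibition, read by MTT assay, with a stated time of 72 h (a lower number here means a stronger inhibitor, a higher number a weaker inhibitor), which is a limit and not a number. Compound 2 `CC(C)[C@H](NC(=O)c1cc(Cl)ccc1OCCCCN)C(=O)Nc1ccc([N+](=O)[O-])cc1Cl` gives > 10000 nM, also a limit. Compound 3 `CC(C)[C@H](NC(=O)c1cc(Cl)ccc1OC1CCNCC1)C(=O)Nc1ccc([N+](=O)[O-])cc1Cl` gives > 10000 nM, again a limit. Compound 1 therefore has no measured potency to compare with, and the evidence so far is the limit of > 10000 nM in this assay, at which 3 of the 3 values shown sit.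

Compound 4 `C[C@H](NC(=O)c1cc(Cl)ccc1OCCN)C(=O)Nc1ccc([N+](=O)[O-])cc1Cl` carries methyl in place of isopropyl on a saturated chain carbon bound to an amide-type nitrogen and a carbonyl carbon. The measured steps are a step that the two limits leave unreadable from compound 1 to compound 2, a step that the two limits leave unreadable from compound 1 to compound 3 and a step that the two limits leave unreadable from compound 2 to compound 3. All three change the group on an oxygen on an aromatic ring, and none touches the isopropyl, so they give neither a size nor a direction for this change.

For the measured compounds named here, the only anchor is compound 1 at > 10000 nM, itself a limit, so compound 4 is expected to remain weak in this assay. The expected change is a step that the limit leaves unreadable from compound 1 to compound 4, an estimate with no firm direction. For compound 4 the estimated value is 15000 nM, with an expected range of 6000 nM to 40000 nM.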

Compound 4, half-maximal inhibitory concentration: > 10000 nM
Compound 4: only a limit was reported (the forecaster's own chance of this, stated with the estimate: 80%); the middle value lies beyond the limit too.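

Compound 4 gives > 10000 nM in this assay, which is a limit and not a number; compound 1 also stands at a limit, so the step between them cannot be read. The compounds shown leave open how either the methyl or the groups on the oxygen affect potency, with the evidence still: the limit of > 10000 nM in this assay, at which 4 of the 4 values shown sit.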